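The source may hold more compounds than are shown below. What is called first, only, known or untested is meant among the compounds shown, and "the series" means these compounds.

Of the compounds shown here, three built on one shared core have been measured in a functional assay on U-251 cells (Homo sapiens) for inhibition, read by sulforhodamine B assay, with a stated time of 48 h; on this read-out lower numbers stand for stronger inhibition and higher numbers for weaker inhibition. Compound 1 `COc1cc(Cl)cc(-c2nn(-c3cccc(NC(=O)Nc4cccc(C(F)(F)F)c4)c3)cc2-c2ccncc2)c1` gives 880 nM in this assay, and compound 2 `COc1cc(Cl)cc(-c2nn(-c3cccc(NC(=O)Nc4ccc(Cl)c(C(F)(F)F)c4)c3)cc2-c2ccncc2)c1` gives 730 nM; the step of a 1.2-fold lower number from compound 1 to compound 2 (0.08 log units; within the scatter) stays within the scatter. Compound 3 `COc1cc(Cl)cc(-c2nn(-c3cccc(NC(=O)c4cccc(C(F)(F)F)c4)c3)cc2-c2ccncc2)c1` gives 5560 nM, the highest of the three numbers, nearest to compound 1 and furthest from compound 2. The steps of a 6.3-fold higher number from compound 1 to compound 3 (0.80 log units; beyond the scatter) and a 7.6-fold higher number from compound 2 to compound 3 (0.88 log units; beyond the scatter) both show a modest rise in the number when 3-(trifluoromethyl)phenyl replaces an arylamino group on the carbonyl carbon.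

Compound 4 `COc1cc(Cl)cc(-c2nn(-c3cccc(NC(=O)Nc4ccc(Cl)c(Cl)c4)c3)cc2-c2ccncc2)c1` has not yet been measured. It differs from compound 3 in one place: (3,4-dichlorophenyl)amino in place of 3-(trifluoromethyl)phenyl on a carbonyl carbon. Read one bond further out, (3-(trifluoromethyl)phenyl)carbonyl becomes (3,4-dichlorophenyl)carbamoyl, which undoes the kind of change that produced the rises to compound 3, while the step of a 1.2-fold lower number from compound 1 to compound 2 (0.08 log units; within the scatter) indicates that chloro on an aromatic carbon alters little. The expected step is therefore a 7.0-fold lower number from compound 3 to compound 4 (0.84 log units; beyond the scatter). Compound 4 is estimated at 800 nM, with a range from 350 nM to 1800 nM.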

Compound 4, half-maximal inhibitory concentration: 1700 nM
The estimate for compound 4 lay 2.1-fold (0.33 log units) below the measured number; low and high end bracket the measured number.
By their numbers in this assay, from the lowest: compounds 2, 1 and 4 (each within the scatter of the next, the first and the last beyond it); then compound 3.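

In this assay, a 3.3-fold lower number from compound 3 to compound 4 (0.51 log units; beyond the scatter) shows that an arylamino group on the carbonyl carbon again goes with a lower number when the aryl group carries no trifluoromethyl, so this link is not tied to that one substituent. Among the arylamino compounds, a 1.9-fold higher number from compound 1 to compound 4 (0.29 log units; within the scatter) stays within the scatter, while a 2.3-fold higher number from compound 2 to compound 4 (0.37 log units; beyond the scatter) lies beyond it, making chloro in place of trifluoromethyl the first change on this phenyl ring to exceed the scatter. Nothing available explains these steps.

On these data alone, it remains open whether a methyl group in place of the amide hydrogen would preserve these numbers. As far as these compounds go, how a methoxy group, an amine or a carboxylic acid on the phenyl ring would read also remains open.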